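The compounds below may be only part of what the source reports. "The series", "measured", "known", "first", "only" and "open" are said of these compounds alone.

In a functional assay on B16-F0 cells (Mus musculus) for inhibition, read by CCK-8 assay, with a stated time of 48 h (a lower number here means a stronger inhibitor, a higher number a weaker inhibitor), compound 1 `COc1cc(-c2ccnc3cc(-c4ccc(Cl)cc4)nn23)cc(OC)c1OC` gives 4090 nM, while compound 2 `COc1cc(-c2ccnc3cc(-c4cn(C)c5ccccc45)nn23)cc(OC)c1OC` gives 185 nM, the lower of the two numbers. Compound 3 `COc1cc(-c2ccnc3cc(-c4cccc(C)c4)nn23)cc(OC)c1OC` has 3-methylphenyl in place of 1-methyl-1H-indol-3-yl on an aromatic carbon of the shared core: 3-methylphenyl in place of 1-methyl-1H-indol-3-yl on an aromatic carbon. Within the data shown here, only one measured step bears on this change. That step, a 22-fold lower number from compound 1 to compound 2 (1.34 log units; beyond the scatter), is large and beyond the scatter, and it introduced the same 1-methyl-1H-indol-3-yl group that compound 3 gives up. Compound 3 returns to a substituted phenyl at that place, as in compound 1, so a large step towards a higher number is expected in this assay. Among the measured compounds shown here, no measurement yet shows how 3-methylphenyl compares with 4-chlorophenyl, so the expectation stays broad. The expected change is a 14-fold higher number from compound 2 to compound 3 (1.13 log units; beyond the scatter). For compound 3 the estimated value is 2500 nM, with an expected range of 700 nM to 9000 nM.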

Compound 3, half-maximal inhibitory concentration: 2220 nM
Beside the measured number, compound 3's estimate is 1.1-fold (0.05 log units) above it; the range from low to high includes it.
By their numbers in this assay, from the lowest: compound 2; then compounds 3 and 1 (each within the scatter of the next).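

In this assay, 3-methylphenyl in place of 1-methyl-1H-indol-3-yl gives a 12-fold higher number from compound 2 to compound 3 (1.08 log units; beyond the scatter), so the low number of compound 2 is not reached by this second substituted phenyl either. The two phenyl groups cannot be told apart at this place on the shared core: 3-methylphenyl in place of 4-chlorophenyl gives a 1.8-fold lower number from compound 1 to compound 3 (0.27 log units; within the scatter), and compounds 1 and 3 stand together, apart from compound 2. No measurement at hand explains why the 1-methyl-1H-indol-3-yl group differs from these phenyl groups.

Going by these compounds, it remains open whether the methyl on the nitrogen of 1-methyl-1H-indol-3-yl matters, as an unmethylated 1H-indol-3-yl group would show. Also open, on these data alone, is whether a pyridine ring or a phenyl carrying an amine would stand with compound 2 or with compounds 1 and 3.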